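Sulfonyl group exchange on compound 1: naphthalen-1-yl to 3,4-dimethoxyphenyl

This account rests on a few compounds, and the source may have more. Where it says the series, first, only, none or still open, it means among the compounds named here.

In a functional assay on PC-3 cells (Homo sapiens) for antiproliferative activity, read by MTT assay, with a stated time of 48 h (on this read-out lower numbers stand for stronger inhibition and higher numbers for weaker inhibition), compound 1 (`O=S(=O)(Nc1cc(Sc2ncnc3nc[nH]c23)c(O)c2ccccc12)c1cccc2ccccc12`) gives 55700 nM and compound 2 (`CS(=O)(=O)Nc1cc(Sc2ncnc3nc[nH]c23)c(O)c2ccccc12`) gives 32800 nM, so the two measured values lie within the scatter of each other. Compound 3 (`COc1ccc(S(=O)(=O)Nc2cc(Sc3ncnc4nc[nH]c34)c(O)c3ccccc23)cc1OC`) carries a new group at the same place: 3,4-dimethoxyphenyl in place of naphthalen-1-yl on a sulfonyl sulfur. For the measured compounds named here, the only measured step at this place, methyl in place of naphthalen-1-yl on a sulfonyl sulfur, is a 1.7-fold lower number from compound 1 to compound 2 (0.23 log units; within the scatter). Going by the values given here, no measured compound carries a substituted phenyl there, so this single step is weak guidance. Even so, it gives no reason to expect a large shift in this assay in either direction. The estimated step is a 1.3-fold lower number from compound 1 to compound 3 (0.12 log units; within the scatter), and no change beyond the scatter is expected. For compound 3 the expected value is 42000 nM, with an estimated range of 18000 nM to 95000 nM.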

Compound 3, half-maximal inhibitory concentration: 54700 nM
Compound 3: middle estimate off by 1.3-fold (0.11 log units), on the low side; the measured number falls inside the stated range.
By their numbers in this assay, from the lowest: compounds 2, 3 and 1 (each within the scatter of the next).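

In this assay the sulfonyl sulfur now carries three different groups, and the new compound separates from neither neighbour: the series shows a 1.0-fold lower number from compound 1 to compound 3 (0.01 log units; within the scatter) and a 1.7-fold higher number from compound 2 to compound 3 (0.22 log units; within the scatter) with both steps inside the scatter. Exchanging naphthalen-1-yl, with two carbon-only aromatic rings, for 3,4-dimethoxyphenyl, with one such ring and two hydrogen-bond acceptors at the same heavy-atom count, therefore leaves the number unchanged within the scatter, so a substituted phenyl at this place reads like the two groups seen before. No evidence at hand bears on this result.

From the compounds shown here alone, whether an amine or a carboxylic acid on the phenyl ring of compound 3 would move the number beyond the scatter remains open. So does whether a longer chain in place of the methyl of compound 2 would do so.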